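This account rests on a few compounds, and the source may have more. Where it says the series, first, only, none or still open, it means among the compounds named here.

In a functional assay on C6 cells (Rattus norvegicus) for cytotoxicity, read by MTT assay, with a stated time of 24 h, tested at 6 ug/mL (on this read-out lower numbers stand for a stronger effect and higher numbers for a weaker effect at the one concentration tested), three compounds built on one shared core have been measured. Compound 1 `Cc1ccc(-c2cs/c(=N/NC(=O)CSc3nnnn3-c3ccccc3)n2-c2ccccc2)cc1` gives 66.8%, compound 2 `O=C(CSc1nnnn1-c1ccccc1)N/N=c1/scc(-c2ccccc2)n1-c1ccccc1` gives 52.1%, and compound 3 `O=C(CSc1nnnn1-c1ccccc1)N/N=c1/scc(-c2ccc(Cl)cc2)n1-c1ccccc1` gives 77.4%. Compound 2 therefore stands lowest of the three, meaning it shows the strongest effect at the single concentration tested; the step of a number 14.7 percentage points lower from compound 1 to compound 2 (beyond the scatter) and the step of a number 25.3 percentage points higher from compound 2 to compound 3 (beyond the scatter) both lie beyond the scatter, as does the step of a number 10.6 percentage points higher from compound 1 to compound 3 (beyond the scatter).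

Compound 4 `Cc1nnc(SCC(=O)N/N=c2/scc(-c3ccccc3)n2-c2ccccc2)s1` has not yet been measured. It differs from compound 2 in one place: 5-methyl-1,3,4-thiadiazol-2-yl in place of 1-phenyl-1H-tetrazol-5-yl on a sulfur. The heteroaromatic ring attached to the sulfur is exchanged, while the rest of the core is kept. None of the three measured steps touches this part of the molecule; all of them swap the group on an aromatic carbon elsewhere in the core, and they moved the read-out by modest amounts. So there is no measured step that bears directly on this exchange, and the expectation must rest on compound 2 alone, with a wide range. On balance, a step no larger than the scatter is expected, a number 2.9 percentage points higher from compound 2 to compound 4 (within the scatter). For compound 4 the estimated value is 55%, within a range from 38% to 75%.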

Compound 4, a percentage reported as activity, at one concentration (the size of the read-out at that concentration, not a potency): 72.4%
Compound 4: the middle estimate sits 17.4 percentage points below what was measured; the range from low to high includes it.
By their numbers in this assay, from the lowest: compound 2; then compounds 1, 4 and 3 (each within the scatter of the next, the first and the last beyond it).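

The earlier steps shown here all changed a group on an aromatic carbon, so they said nothing about the group on the sulfur. In this assay, exchanging 1-phenyl-1H-tetrazol-5-yl for 5-methyl-1,3,4-thiadiazol-2-yl gives a number 20.3 percentage points higher from compound 2 to compound 4 (beyond the scatter), which means a weaker effect at the one concentration tested and shows that the read-out responds to this position as well. The change goes in the same direction as chloro in place of hydrogen on an aromatic carbon, a number 25.3 percentage points higher from compound 2 to compound 3 (beyond the scatter), although the two changes sit in different parts of the molecule, and nothing available here explains why the read-out moves with the exchange on the sulfur.

This single exchange alters two things at once, since the entering group has a different five-membered ring and also lacks the phenyl ring of the group that leaves, so the compounds shown cannot tell which of these matters. As far as these compounds go, a tetrazole carrying methyl in place of phenyl on the same sulfur would separate the two, and it also remains open whether the chloro and methyl steps on the aromatic carbon hold with the thiadiazole in place.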